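Replacing 5-Methylthiophen-2-yl with 4-Chlorophenyl in Growth Inhibitors

The source may hold more compounds than are shown below. What is called first, only, known or untested is meant among the compounds shown, and "the series" means these compounds.

In a functional assay on DU-145 cells (Homo sapiens) for inhibition, read by trypan blue exclusion, with a stated time of 96 h (a lower number here means a stronger inhibitor of growth, a higher number a weaker inhibitor of growth), compound 1 `Cc1ccc(S/C(=C/c2ccc(Cl)cc2)C(=O)c2ccc(Br)cc2)cc1` gives 10000 nM.
Compound 2 `Cc1ccc(S/C(=C/c2ccc(C)s2)C(=O)c2ccc(Br)cc2)cc1` gives only a limit in this assay, > 100000 nM.
Compound 3 `Cc1ccc(/C=C(/SCc2ccc(F)cc2)C(=O)c2ccc(Cl)cc2)s1` likewise gives only a limit in this assay, > 100000 nM.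

Going by the values given here, two of the three measured values sit at the limit (the limit of > 100000 nM in this assay, at which 2 of the 3 values shown sit), so only one step is known in size: an at least 10-fold lower number from compound 2 to compound 1 (1.00 log units; beyond the scatter), brought about by 4-chlorophenyl in place of 5-methylthiophen-2-yl on a double-bonded chain carbon bound to a double-bonded chain carbon. The difference between the core of compound 2 and the core of compound 3 is not broken down here. Compound 4 `O=C(/C(=C\c1ccc(Cl)cc1)SCc1ccc(F)cc1)c1ccc(Cl)cc1` carries the same change made on compound 3, namely (4-chlorophenyl in place of 5-methylthiophen-2-yl on a double-bonded chain carbon bound to a double-bonded chain carbon), at the same place. Compound 4 is therefore expected to show a step of about an at least 5.0-fold lower number from compound 3 to compound 4 (0.69 log units; beyond the scatter) in this assay, resting on the step of an at least 10-fold lower number from compound 2 to compound 1 (1.00 log units; beyond the scatter), though the starting point for compound 3 is itself only a limit. Compound 4 is estimated at 20000 nM, with a likely range from 5000 nM to 100000 nM.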

Compound 4, concentration for 50% growth inhibition: 10000 nM
Estimate against measurement, compound 4: 2.0-fold (0.30 log units) above; the measured number falls inside the stated range.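

In this assay the change from 5-methylthiophen-2-yl to 4-chlorophenyl also lowers the number on a second core, with an at least 10-fold lower number from compound 3 to compound 4 (1.00 log units; beyond the scatter), so the direction of the step carries over from one core to the other. Compound 3 gives only a limit, > 100000 nM. From the compounds shown here alone, the true size of this step remains unknown, and so does any difference between the cores: the same change on two cores in this assay, an at least 10-fold lower number (1.00 log units; beyond the scatter) from compound 2 to compound 1 and an at least 10-fold lower number (1.00 log units; beyond the scatter) from compound 3 to compound 4; the limit leaves it open whether they differ.

The compounds shown leave open how a plain phenyl would compare on a double-bonded chain carbon bound to a double-bonded chain carbon. Also open, going by these compounds, is what an amine or a carboxylic acid would do in place of the chlorine of 4-chlorophenyl.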